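The source may report more compounds than this note shows. Statements on the series, on what has been measured and on what is new or still open speak of the compounds shown alone.

The three measured compounds share one core and differ only in the group on the carbonyl carbon: compound 1 `Cc1nc(C(=O)Nc2ccc(Cl)c(-c3nnc4c(Cl)cccn34)c2)cs1` carries a 2-methyl-1,3-thiazol-4-yl, compound 2 `O=C(Nc1ccc(Cl)c(-c2nnc3c(Cl)cccn23)c1)c1cccc(Cl)c1` a 3-chlorophenyl, and compound 3 `CS(=O)(=O)c1cccc(C(=O)Nc2ccc(Cl)c(-c3nnc4c(Cl)cccn34)c2)c1` a 3-(methylsulfonyl)phenyl. In a functional assay on HeLa cells (Homo sapiens) for antiproliferative activity, read by MTT assay, with a stated time of 72 h (on this read-out lower numbers stand for stronger inhibition and higher numbers for weaker inhibition), compound 1 gives 79800 nM. In this assay compound 3 gives 86400 nM. Compound 2 stands at the limit of > 100000 nM in this assay, at which 1 of the 3 values shown sits, so for it there is a limit, > 100000 nM, and not a number. The two steps that touch compound 2 are small: an at least 1.2-fold higher number from compound 1 to compound 2 (0.09 log units; that floor lies within the scatter) and an at least 1.1-fold lower number from compound 2 to compound 3 (0.06 log units; that floor lies within the scatter), neither of which moves beyond the usual scatter.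

Compound 4 `O=C(Nc1ccc(Cl)c(-c2nnc3c(Cl)cccn23)c1)c1cccnc1` is the next member. Compared with compound 2 it shows (pyridin-3-yl in place of 3-chlorophenyl on a carbonyl carbon). Both measured steps into and out of compound 2 sit at the same carbonyl carbon or on the ring it carries, and both stayed within the scatter, so for this exchange of one six-membered aromatic ring for another at the same place a step of similar size is expected, that is an at least 1.1-fold lower number from compound 2 to compound 4 (0.04 log units; that floor lies within the scatter), with no clear direction. Compound 4 is therefore estimated at 90000 nM in this assay, within a range from 45000 nM to 180000 nM.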

Compound 4, half-maximal inhibitory concentration: > 100000 nM
Compound 4: a limit, no number; the forecaster's own chance of this, stated with the estimate: 40%; middle value at least 1.1-fold (0.04 log units) away from the limit.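

Compound 4, like compound 2, gives a limit and not a number, so a pyridin-3-yl on the carbonyl carbon adds a second compound at that limit and the step between these two cannot be read: the limit of > 100000 nM in this assay, at which 2 of the 4 values shown sit.

The two steps that can be read run to the compounds with numbers: an at least 1.1-fold higher number from compound 3 to compound 4 (0.06 log units; that floor lies within the scatter) and an at least 1.2-fold higher number from compound 1 to compound 4 (0.09 log units; that floor lies within the scatter). Within the data shown here, both are only floors, so they do not tell how large the real steps are, yet across the four groups now seen on this carbonyl carbon, including a ring with a nitrogen and a hydrogen-bond acceptor, no step is printed as beyond the scatter.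

As far as these compounds go, whether any group at this place can bring a number clearly apart from these in this assay stays open, for instance a saturated ring with an amine such as piperidin-4-yl, or a phenyl ring carrying a carboxylic acid. Also open, from the compounds shown here alone, is whether an aromatic ring is needed here at all, which a simple alkyl chain such as ethyl on the carbonyl carbon would speak to.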